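Methoxy to Methyl Step Across Two Cores

The source may hold more compounds than are shown below. What is called first, only, known or untested is meant among the compounds shown, and "the series" means these compounds.

Measured in a functional assay on the whole organism for inhibition, with Brassica napus as the target, with a stated time of 72 h, tested at 10 mg/L; on this read-out higher numbers stand for more inhibition of growth at the one concentration tested and lower numbers for less inhibition of growth:
compound 1 `COc1cc(C)nc2n/c(=N/C(=O)c3c(-c4ccc(Cl)cc4Cl)noc3C)sn12`: compound 1 gives 26.4%
compound 2 `COc1cc(OC)n2s/c(=N\C(=O)c3c(-c4ccc(Cl)cc4Cl)noc3C)nc2n1`: compound 2 gives 49.3%
compound 3 `COc1cc(OC)nc(NC(=S)NC(=O)c2c(-c3ccc(Cl)cc3Cl)noc2C)n1`: compound 3 gives 35.2%

Compound 1 and compound 2 share one core; compound 1 carries methyl in place of methoxy on an aromatic carbon, and the step is a number 22.9 percentage points lower from compound 2 to compound 1 (beyond the scatter). Compound 3 has another core; the difference between the two cores is not broken down here.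

Compound 4 `COc1cc(C)nc(NC(=S)NC(=O)c2c(-c3ccc(Cl)cc3Cl)noc2C)n1` differs from compound 3 by methyl in place of methoxy on an aromatic carbon. The surroundings are not the same as in compound 1, where the carbon sits in a ring that is part of a fused or bridged system of two rings, meta to a fused ring and para to a fused ring, whereas in compound 4 it is meta to a large group; this is the same kind of change, not the same. The step from compound 3 to compound 4 is expected at a number 15.2 percentage points lower from compound 3 to compound 4 (beyond the scatter), resting on a number 22.9 percentage points lower from compound 2 to compound 1 (beyond the scatter) and on the changed surroundings. Compound 4 is estimated at 20%, expected between 6% and 34%.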

Compound 4, percent growth inhibition at one concentration: 15.7%
Compound 4: the middle estimate sits 4.3 percentage points above what was measured; low and high end bracket the measured number.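

In this assay, methyl in place of methoxy on an aromatic carbon gives a number 19.5 percentage points lower from compound 3 to compound 4 (beyond the scatter), and this step agrees with the earlier one on the other core: the same change on two cores in this assay, a number 22.9 percentage points lower (beyond the scatter) from compound 2 to compound 1 and a number 19.5 percentage points lower (beyond the scatter) from compound 3 to compound 4, 3.4 percentage points apart, within the scatter of two such steps

The change therefore carries over between these two cores with much the same size, at the one concentration tested. This does not show that it would hold on any further core, and two steps neither set a general rule nor explain why the number falls.

Open, as far as these compounds go, is whether an amine, a chlorine or an ethoxy group in the same place would follow the same step. Also open, from the compounds shown here alone, is what replacing the remaining methoxy group of compound 4 would do to the number.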